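Swapping the pendant ring in a fused sulfonamide series

This account rests on a few compounds, and the source may have more. Where it says the series, first, only, none or still open, it means among the compounds named here.

Of the compounds shown here, two of a shared core have been measured in a functional assay on Ehrlich cells (Mus musculus) for antiproliferative activity, read by trypan blue exclusion, with a stated time of 2 h, tested at 10 ug/mL; a higher number here means a stronger effect of the compound at the concentration tested, a lower number a weaker effect. Compound 1, `COc1ccc(C2C(C#N)=C(N)N(c3ccc(S(N)(=O)=O)cc3)C3=C2C(=O)CCC3)cc1`, gives 30%. Compound 2, `N#CC1=C(N)N(c2ccc(S(N)(=O)=O)cc2)C2=C(C(=O)CCC2)C1c1cccc([N+](=O)[O-])c1`, gives 42%. Compound 2 stands highest of the two numbers; its nearest neighbour is compound 1, and the step of a number 12 percentage points higher from compound 1 to compound 2 (beyond the scatter) is the only one recorded. That step bears directly on the question here. It also changes the group on a saturated ring carbon, though to a different ring.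

Compound 3, `N#CC1=C(N)N(c2ccc(S(N)(=O)=O)cc2)C2=C(C(=O)CCC2)C1c1cccs1`, is not yet measured. It differs from compound 2 as follows: thiophen-2-yl in place of 3-nitrophenyl on a saturated ring carbon. Going by the values given here, no measured step shows what this particular exchange does. Among the compounds with values here, since the one known change at this position moved the read-out by a modest amount, a step of similar or smaller size is expected, more likely downward from the highest value than upward, and possibly within the scatter. The estimated step is a number 8 percentage points lower from compound 2 to compound 3 (within the scatter). For compound 3 the expected result in this assay is 34%, with a range from 18% to 50%.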

Compound 3, a percentage reported as activity, at one concentration (the size of the read-out at that concentration, not a potency): 70%
Compound 3: the middle estimate sits 36 percentage points below what was measured, and the stated range ends below it.
By their numbers in this assay, from the lowest: compound 1; then compound 2; then compound 3.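

Moving from one substituted six-memberd aromatic ring to another on this saturated ring carbon gave only a small part of the range this position can span in this assay: the thiophen-2-yl group produces a rise (a number 28 percentage points higher from compound 2 to compound 3 (beyond the scatter)) well above the earlier change (a number 12 percentage points higher from compound 1 to compound 2 (beyond the scatter)), and a still larger one against the 4-methoxyphenyl compound (a number 40 percentage points higher from compound 1 to compound 3 (beyond the scatter)). Among these three compounds, then, the five-membered aromatic ring with a sulfur atom stands highest, and both compounds with a six-membered aromatic ring of carbon only lie clearly lower. No independent measurement bears on why this exchange has such an effect.

The exchange alters the ring size, brings in sulfur and removes the nitro or methoxy substituent all at once, so these compounds cannot show which of these changes matters. On these data alone, how an unsubstituted phenyl, a furan-2-yl or thiophen-3-yl ring, a substituted thiophene, or a non-aromatic group such as cyclohexyl would behave on this same carbon remains open.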